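The compounds below may be only part of what the source reports. "The series", "measured", "known", "first", "only" and "open" are said of these compounds alone.

Working notes on the series.

Compound 1 `COc1cc(OC)c2c(=O)cc(-c3ccc(OCCBr)cc3)oc2c1` is the reference point here. In a functional assay (Homo sapiens) for antiproliferative activity, read by resazurin assay, with a stated time of 48 h, tested at 5 uM (a lower number here means a weaker effect, a higher number a stronger effect of the compound at the concentration tested), compound 1 is recorded as "not active" (no number reported), so no number places it on the scale; it stands only as a compound for which no effect was found at the test concentration. The measured numbers in this set come from two other members of the same core. Compound 2 `COc1cc(OC)c2c(=O)cc(-c3ccc(OC4CCN(C)CC4)cc3)oc2c1` gives 28% in this assay, and compound 3 `COc1cc(OC)c2c(=O)cc(-c3ccc(OCCN4CCCC4=O)cc3)oc2c1` gives 7%. Within the data shown here, the one step that can be read between them, a number 21 percentage points lower from compound 2 to compound 3 (beyond the scatter), concerns the group carried on the aromatic oxygen and is the only measured step in the set.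

Compound 4 `COc1cc(OC)c2c(=O)cc(-c3ccc(OCCN)cc3)oc2c1` is the next member to be measured. It differs from compound 1 by amino in place of bromo on a saturated chain carbon, two bonds along the chain from an oxygen on an aromatic ring. Among the measured compounds shown here, no measured step covers this exchange: the step from compound 2 to compound 3 changes the ring-bearing group on the aromatic oxygen, not the end of a two-carbon chain, so it bears on compound 4 only by showing that changes at this position shift this assay by a modest amount and that compounds in the set reach, at most, the level of compound 2. The starting point carries no number, so no direction can be read. Compound 4 is therefore estimated at 15%, with a range from 0% to 35%, and a real chance that it is again reported without a number.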

Compound 4, a percentage reported as inhibition, at one concentration (the size of the read-out at that concentration, not a potency): 6%
Compound 4: middle estimate off by 9 percentage points, on the high side; the range from low to high includes it.
By their numbers in this assay, from the lowest: compounds 4 and 3 (each within the scatter of the next); then compound 2.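

Compound 1 carries no number, so the step from bromo to amino cannot be read, but compound 4 gives the 2-aminoethoxy group its first measured place in this assay. With a number 1 percentage points lower from compound 3 to compound 4 (within the scatter), the amino and 2-oxopyrrolidin-1-yl ends of the chain cannot be told apart in this assay, even though only one of them brings a ring. With a number 22 percentage points lower from compound 2 to compound 4 (beyond the scatter), the gap already seen for compound 3 appears a second time with a different chain end, so compound 2 with its 1-methylpiperidin-4-yl group stands clear of both chain compounds, though the pattern rests on these three numbers alone.

No evidence at hand explains any of these differences. As far as these compounds go, it remains open whether the level of compound 2 can be reached by a chain-linked group, for example a dimethylamino or carboxylic acid end on the 2-carbon chain, or an amino end on a longer chain, and whether a 1-methylpiperidin-4-yl group set at the end of the chain would behave as it does directly on the oxygen.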